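Moving the chlorine on the phenoxy tail

The compounds below may be only part of what the source reports. "The series", "measured", "known", "first", "only" and "open" are said of these compounds alone.

Compound 1 `NC1=NC2(CCSCC2)N(OCCCOc2cccc(Cl)c2)C(N)=N1` is one of three close analogues tested in an assay on isolated protein for inhibition of Dihydrofolate reductase (Homo sapiens), read by spectrophotometry, using NADPH, with stated times of 5 s and 6 min, tested at 5 uM; a lower number here means a weaker effect, a higher number a stronger effect of the compound at the concentration tested. Compound 1 gives 88.3%, the higher of the two numbers reported, though the gap to compound 2 is within the scatter. Compound 2 `Cc1cc(C)cc(OCCCON2C(N)=NC(N)=NC23CCOCC3)c1` gives 84.3%. Compound 3 `NC1=NC2(CCOCC2)N(OCCCOc2ccc(Cl)cc2Cl)C(N)=N1` reaches > 90%, a limit of the assay rather than a number. For the measured compounds named here, the one measured step, a number at least 5.7 percentage points higher from compound 2 to compound 3 (that floor lies within the scatter), can only be read as a floor because the limit of > 90% in this assay, at which 1 of the 3 values shown sits, caps what it shows. Compound 4 `NC1=NC2(CCSCC2)N(OCCCOc2ccc(Cl)cc2)C(N)=N1` differs from compound 1 by 4-chlorophenyl in place of 3-chlorophenyl on an oxygen on a saturated carbon. Going by the values given here, no measured step tests this change directly, and the aryl variations seen here give numbers close together. Compound 4 is therefore expected to show 89%, between 82% and 94%. The step of a number 0.7 percentage points higher from compound 1 to compound 4 (within the scatter) is estimated to stay within the scatter.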

Compound 4, a percentage reported as inhibition, at one concentration (the size of the read-out at that concentration, not a potency): > 90%
Compound 4: a limit, no number (the forecaster's own chance of this, stated with the estimate: 30%); middle value at least 1 percentage points away from the limit.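

For the compounds shown here, with the core held fixed, the chlorine was moved on the phenoxy tail, and in this assay this gives a first direct reading of the change from 3-chlorophenyl to 4-chlorophenyl, with no sign of lost inhibition: a number at least 1.7 percentage points higher from compound 1 to compound 4 (that floor lies within the scatter). Compound 4 gives > 90%, which is a limit of the assay and not a number. The true size of the step cannot be read because the read-out is capped: the limit of > 90% in this assay, at which 2 of the 4 values shown sit. On these data alone, it remains open whether an amine or a carboxylic acid in place of the chlorine would keep this level of inhibition.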